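Styryl oxadiazole sulfonamides: swapping the aryl halogen pattern

A few compounds are considered here, and "the series" means these few. Any claim that something is new, unique, unknown or untested is made for them only; others in the source may bear on it.

Within the data shown here, compound 2 `NS(=O)(=O)c1cc(-c2nnc(/C=C/c3c(Cl)cccc3Cl)o2)c(Cl)cc1SCc1ccccc1` gives 29000 nM in a functional assay on MCF7 cells (Homo sapiens) for cytotoxicity, read by MTT assay, with a stated time of 72 h (a lower number here means a stronger inhibitor, a higher number a weaker inhibitor), and is the lowest of the two numbers recorded; compound 1 `CC(C)(O)c1cn(Cc2nnc(-c3cc(S(N)(=O)=O)c(SCc4ccccc4)cc3Cl)o2)nn1` gives 168000 nM, and a 5.8-fold lower number from compound 1 to compound 2 (0.76 log units; beyond the scatter) marks the only measured step. Compound 3 `NS(=O)(=O)c1cc(-c2nnc(/C=C/c3ccc(Br)cc3)o2)c(Cl)cc1SCc1ccccc1` carries 4-bromophenyl in place of 2,6-dichlorophenyl on a double-bonded chain carbon bound to a double-bonded chain carbon. Among the measured compounds shown here, no measured step touches this aryl change, so the earlier step offers no direct guide, and no shift beyond the scatter is expected. Compound 3 is therefore estimated at 35000 nM, between 12000 nM and 100000 nM, a step of a 1.2-fold higher number from compound 2 to compound 3 (0.08 log units; within the scatter) from compound 2.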

Compound 3, half-maximal inhibitory concentration: 13000 nM
Beside the measured number, compound 3's estimate is 2.7-fold (0.43 log units) above it; measured number inside the range.
By their numbers in this assay, from the lowest: compound 3; then compound 2; then compound 1.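

Moving from 2,6-dichlorophenyl to 4-bromophenyl on the double-bonded chain carbon gives a 2.2-fold lower number from compound 2 to compound 3 (0.35 log units; beyond the scatter) in this assay, so this aryl group alone moves the number beyond the scatter. Replacing the triazolylmethyl group of compound 1 with 2-(4-bromophenyl)ethenyl gives a large change, a 13-fold lower number from compound 1 to compound 3 (1.11 log units; beyond the scatter) and compound 3 holds the lowest number of the set. Nothing available explains either step. The swap changes the halogen and its place together, leaving their separate contributions open. A 4-chlorophenyl or an unsubstituted phenyl on the same chain would separate them.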